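Aryl variation on the oxadiazole-linked pyridazinone series

This account rests on a few compounds, and the source may have more. Where it says the series, first, only, none or still open, it means among the compounds named here.

Measured so far in a functional assay on the whole organism for inhibition, with Mythimna separata as the target, with a stated time of 5 days; on this read-out lower numbers stand for an effect already at smaller amounts and higher numbers for an effect only at larger amounts of compound:
compound 1 `CC(C)(C)n1ncc(OCc2nnc(-c3ccc(Cl)cc3)s2)c(Cl)c1=O` gives 106 ug/mL;
compound 2 `Cc1cc(C)cc(-c2nnc(COc3cnn(C(C)(C)C)c(=O)c3Cl)s2)c1` gives > 300 ug/mL, a limit of the assay and not a number;
compound 3 `CC(C)(C)n1ncc(OCc2nnc(-c3cccc(F)c3)o2)c(Cl)c1=O` gives 7.1 ug/mL.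

Compound 3 holds the lowest of the two numbers in this assay; the nearest is compound 1, a considerable distance away. Compound 4 `CCc1ccc(-c2nnc(COc3cnn(C(C)(C)C)c(=O)c3Cl)o2)cc1` has not yet been measured. Its change from compound 3 is 4-ethylphenyl in place of 3-fluorophenyl on an aromatic carbon, on an aromatic carbon of a five-membered aromatic ring with 2 nitrogen and 1 oxygen.

For the measured compounds named here, one measured step bears on it: an at least 2.8-fold higher number from compound 1 to compound 2 (0.45 log units; beyond the scatter), where a halogen-bearing phenyl gave way to an alkyl-bearing phenyl on an aromatic carbon. The step from compound 3 to compound 4 likewise exchanges a halogen-bearing phenyl for an alkyl-bearing one, so a higher number in this assay of modest size is expected; the shift may be smaller than in the measured step since compound 2 sits at a limit (the limit of > 300 ug/mL in this assay, at which 1 of the 3 values shown sits).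

Compound 4 is therefore estimated at 25 ug/mL, between 7 ug/mL and 120 ug/mL, which means an expected step of a 3.5-fold higher number from compound 3 to compound 4 (0.55 log units; beyond the scatter).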

Compound 4, half-maximal effective concentration: 14.5 ug/mL
Compound 4: middle estimate off by 1.7-fold (0.24 log units), on the high side; low and high end bracket the measured number.
By their numbers in this assay, from the lowest: compound 3; then compound 4; then compound 1. At a limit, above all of these: compound 2.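

In this assay, 4-ethylphenyl in place of 3-fluorophenyl on this aromatic carbon of the five-membered ring with 2 nitrogen and 1 oxygen gives a 2.0-fold higher number from compound 3 to compound 4 (0.31 log units; beyond the scatter), so an alkyl-bearing phenyl at this place still returns a number. Both listed steps from a halogen-bearing to an alkyl-bearing phenyl go to a higher number, and this new step is the first of the two with a number at each end. The earlier step, an at least 2.8-fold higher number from compound 1 to compound 2 (0.45 log units; beyond the scatter), ends on compound 2, whose value is a limit of the assay and not a number: the limit of > 300 ug/mL in this assay, at which 1 of the 4 values shown sits.

The new step swaps the substituent and its place on the phenyl at once, which leaves the share of each unresolved. Going by these compounds, how a phenyl carrying a dimethylamino group or a carboxylic acid would read at this place also stays open.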